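Methyl on a Ring Nitrogen: Expecting No Gain in Inhibition

The source may report more compounds than this note shows. Statements on the series, on what has been measured and on what is new or still open speak of the compounds shown alone.

Measured compounds:
Compound 1: `c1ccc(Sc2ncnc3[nH]cnc23)cc1`, giving 0%
Compound 2: `c1ccc(CSc2ncnc3[nH]cnc23)cc1`, giving 0%

Both compounds were tested in an assay on isolated protein for inhibition of Ca2+/calmodulin-dependent protein kinase II (CaM kinase II) (Rattus norvegicus), tested at 30 uM; a lower number here means less inhibition, a higher number more inhibition at the concentration tested (going by the name of the read-out). In that assay compound 1 gives 0%, and compound 2 gives 0%. Compound 2 thus stands level with compound 1 at the digits reported, the two values lying within the usual scatter of each other, and neither compound shows measurable inhibition at the concentration used.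

Compound 3, `Cn1cnc2c(SCc3ccccc3)ncnc21`, has not yet been measured. It differs from compound 2 in one place: methyl in place of hydrogen on an aromatic nitrogen. Among the measured compounds shown here, no measured pair covers this kind of change, since both measured compounds carry hydrogen on that ring nitrogen. For the measured compounds named here, with nothing among the measured compounds pointing toward inhibition, the step of no change at the digits printed from compound 2 to compound 3 (within the scatter) is expected to be none beyond the scatter. Compound 3 is therefore estimated at 0%, with a range from 0% to 10%.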

Compound 3, a percentage reported as inhibition, at one concentration (the size of the read-out at that concentration, not a potency): 0%
Compound 3: middle estimate and measured number agree at the digits printed; measured number inside the range.
By their numbers in this assay, from the lowest: compounds 1, 2 and 3 (each within the scatter of the next).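

Methyl in place of hydrogen on an aromatic nitrogen of the five-membered aromatic ring brings no change at the digits printed from compound 2 to compound 3 (within the scatter) in this assay and so adds a first change on that ring nitrogen to the two compounds with hydrogen there. Compound 2 already stood at 0% before the change, so this result shows that methyl does not bring inhibition into view, but it cannot show whether methyl would weaken inhibition, since a compound without measurable inhibition has none to lose. No measurement at hand offers an explanation for this outcome.

From the compounds shown here alone, whether a longer chain on this nitrogen would behave as methyl does remains open. So does the question of whether an amine or a carboxylic acid elsewhere on the shared core would produce any measurable inhibition in this assay at all.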